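Tolerance limit in Vero cells, and a fluorinated swap

The source may hold more compounds than are shown below. What is called first, only, known or untested is meant among the compounds shown, and "the series" means these compounds.

- compound 1 `O=c1nc(N2CCN(CC3CCCCC3)CC2)sc2c([N+](=O)[O-])cc(C(F)(F)F)cc12` gives > 64 ug/mL as a limit
- compound 2 `CC(c1ccc(C(F)(F)F)cc1)N1CC2(CCN(c3nc(=O)c4cc(C(F)(F)F)cc([N+](=O)[O-])c4s3)CC2)C1` gives > 64 ug/mL as a limit

In an ADME assay on Vero cells (Chlorocebus sabaeus) for cytotoxicity (a lower number here means that less compound is tolerated, a higher number that more compound is tolerated), compound 2 stands at > 64 ug/mL as a limit of the assay and not a number. Both measured compounds share that position (the limit of > 64 ug/mL in this assay, at which 2 of the 2 values shown sit). Compound 3 `CC(c1cc(F)c(F)c(F)c1)N1CC2(CCN(c3nc(=O)c4cc(C(F)(F)F)cc([N+](=O)[O-])c4s3)CC2)C1` carries 3,4,5-trifluorophenyl in place of 4-(trifluoromethyl)phenyl (3,4,5-trifluorophenyl in place of 4-(trifluoromethyl)phenyl on a saturated chain carbon bound to an amine nitrogen in a ring and a saturated chain carbon) on a saturated chain carbon bound to an amine nitrogen in a ring and a saturated chain carbon. The step (a number no higher from compound 2 to compound 3 (the limit leaves the size open)) is expected to stay within the scatter, and another limit is likely. For compound 3 the estimated value is 64 ug/mL with an expected range from 32 ug/mL to 128 ug/mL until it is measured.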

Compound 3, half-maximal cytotoxic concentration: > 64 ug/mL
Compound 3: no number, only a limit; the forecaster's own chance of this, stated with the estimate: 75%; the middle value lies on the limit itself.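

In this assay, for the compounds shown here, compound 2 and compound 3 both give a limit of the assay and not a number, so no step between them can be read. The compounds shown leave open where the half-maximal cytotoxic concentration of each lies, and whether 3,4,5-trifluorophenyl in place of 4-(trifluoromethyl)phenyl alters it at all.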